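A Pyrimidine Amide Swap Carried Across Two Cores

The source may hold more compounds than are shown below. What is called first, only, known or untested is meant among the compounds shown, and "the series" means these compounds.

Compound 1 `COc1ccc(C(=O)Nc2cc(Nc3nccc(-c4cn(C)c5ccccc45)n3)c(OC)cc2N(C)C)nc1` and compound 2 `COc1cc(N(C)C)c(NC(=O)c2ccncn2)cc1Nc1nccc(-c2cn(C)c3ccccc23)n1` share one core and differ in a single place. In a functional assay on A549 cells (Homo sapiens) for antiproliferative activity, read by MTT assay, with a stated time of 72 h (on this read-out higher numbers stand for weaker inhibition and lower numbers for stronger inhibition), compound 1 gives 5150 nM. In this assay compound 2 gives 5160 nM. The change between them is pyrimidin-4-yl in place of 5-methoxypyridin-2-yl on a carbonyl carbon, and it made a 1.0-fold higher number from compound 1 to compound 2 (0.00 log units; within the scatter), so the two amides cannot be told apart on this read-out.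

Compound 3 `COc1ccc(C(=O)Nc2cc(Nc3nc(-c4cn(C)c5ccccc45)c4cccnc4n3)c(OC)cc2N(C)CCN(C)C)nc1` rests on a different core; how the two cores differ is not broken down here. In this assay compound 3 gives 4230 nM, a number within the scatter of both compound 1 and compound 2, so no order among the three can be claimed.

Compound 4 `COc1cc(N(C)CCN(C)C)c(NC(=O)c2ccncn2)cc1Nc1nc(-c2cn(C)c3ccccc23)c2cccnc2n1` has not been measured. Within the data shown here, it differs from compound 3 by pyrimidin-4-yl in place of 5-methoxypyridin-2-yl on a carbonyl carbon, the same change, at the same place, as the one that leads from compound 1 to compound 2. Among the measured compounds shown here, since that earlier pair moved only a 1.0-fold higher number from compound 1 to compound 2 (0.00 log units; within the scatter), a step of similar size is expected here, and the new core is assumed to leave the pattern untouched, an assumption supported by only one pair so far. Compound 4 is therefore expected to give 4300 nM in this assay, most likely between 2400 nM and 8000 nM. The step this estimate means is a 1.0-fold higher number from compound 3 to compound 4 (0.01 log units; within the scatter), expected to stay within the usual scatter because the earlier step was a 1.0-fold higher number from compound 1 to compound 2 (0.00 log units; within the scatter).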

Compound 4, half-maximal inhibitory concentration: 4520 nM
Compound 4: middle estimate off by 1.1-fold (0.02 log units), on the low side; low and high end bracket the measured number.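

On the core of compound 3, pyrimidin-4-yl in place of 5-methoxypyridin-2-yl on a carbonyl carbon gives a 1.1-fold higher number from compound 3 to compound 4 (0.03 log units; within the scatter) in this assay, so the two amides again cannot be told apart on this read-out. Set beside the earlier pair, the two steps agree, and in this series the swap carries from one core to the other without a difference that can be read: the same change on two cores in this assay, a 1.0-fold higher number (0.00 log units; within the scatter) from compound 1 to compound 2 and a 1.1-fold higher number (0.03 log units; within the scatter) from compound 3 to compound 4, 1.1-fold (0.03 log units) apart, within the scatter of two such steps This does not show that the core has no influence on the change in general, as the agreement rests on only two pairs, in one assay, and both steps are too small to reveal how a real effect of the swap would transfer between cores, nor do they explain why the swap is silent here.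

The compounds shown leave open whether the silence is particular to these two six-membered aromatic rings or would extend to other groups on the carbonyl carbon, such as a plain phenyl ring, a morpholine or a carboxylic acid. They also leave open whether any group at this place would separate the amides on either core in this assay.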